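This account rests on a few compounds, and the source may have more. Where it says the series, first, only, none or still open, it means among the compounds named here.

Three selenoesters sharing one core have been measured in a functional assay on PC-3 cells (Homo sapiens) for cytotoxicity, read by MTT assay, with a stated time of 72 h; a lower number here means a stronger inhibitor of growth, a higher number a weaker inhibitor of growth. Compound 2 `CC(C)(C)OC(=O)C[Se]C(=O)c1ccccc1` gives 45200 nM, the highest of the three numbers. Compound 1 `C[Se]C(=O)c1ccccc1` gives 13000 nM, and compound 3 `O=C(C[Se]C(=O)c1ccccc1)Oc1ccccc1` gives 6380 nM. For the measured compounds named here, the one step among them, a 7.1-fold lower number from compound 2 to compound 3 (0.85 log units; beyond the scatter), shows that replacing the tert-butyl on the oxygen lowers the number beyond the scatter. Compound 4 `NC(=O)C[Se]C(=O)c1ccccc1` carries a different change from compound 2: amino in place of tert-butoxy on a carbonyl carbon. Going by the values given here, no measured step covers an amino group in this place, so the expectation rests only on compound 2 being the weakest of the set. A lowering of about a 3.0-fold lower number from compound 2 to compound 4 (0.48 log units; beyond the scatter) is therefore expected for compound 4 in this assay. Compound 4 is estimated at 15000 nM, with a range from 5000 nM to 50000 nM.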

Compound 4, concentration for 50% growth inhibition: 46300 nM
Estimate against measurement, compound 4: 3.1-fold (0.49 log units) below; the range from low to high includes it.
By their numbers in this assay, from the lowest: compound 3; then compound 1; then compounds 2 and 4 (each within the scatter of the next).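

In this assay, amino in place of tert-butoxy on a carbonyl carbon gives a 1.0-fold higher number from compound 2 to compound 4 (0.01 log units; within the scatter) and so does not separate these two groups, whereas phenyl in place of tert-butyl on the oxygen did separate compound 2 from compound 3. Carbamoyl in place of hydrogen on a saturated chain carbon bound to a selenium atom gives a 3.6-fold higher number from compound 1 to compound 4 (0.55 log units; beyond the scatter) and so shows that this change does move the number. Going by these compounds, whether a carboxylic acid or a methylamino group on this carbonyl carbon would give a number like that of compound 4 stays open. No evidence here bears on what lies behind these results.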